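Replacing the Phenoxy Group on the Side Chain

This account rests on a few compounds, and the source may have more. Where it says the series, first, only, none or still open, it means among the compounds named here.

Measured so far:
compound 1 `O=C(O)CC/C=C\CC1COC(c2cccs2)OC1c1cccnc1`, 71 nM
compound 2 `CC(C)(Oc1ccccc1)C1OCC(C/C=C\CCC(=O)O)C(c2cccnc2)O1`, 52 nM

Both values come from an assay for inhibition of Thromboxane-A synthase (Homo sapiens), using microsomes; on this read-out higher numbers stand for weaker inhibition and lower numbers for stronger inhibition. Compound 2 holds the lowest number of the two, and compound 1 sits a small distance above it: a 1.4-fold lower number from compound 1 to compound 2 (0.14 log units; within the scatter). That one step replaced a five-membered aromatic group with a larger six-membered one on a saturated ring carbon, and it moved the number hardly at all.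

Compound 3 `Cc1ccc(SC(C)(C)C2OCC(C/C=C\CCC(=O)O)C(c3cccnc3)O2)c([N+](=O)[O-])c1` is not yet measured. It differs from compound 2 in a single place: a group of 11 heavy atoms (7 carbon, 1 nitrogen, 2 oxygen, 1 sulfur; one six-membered aromatic ring of carbon only) in place of a group of 7 heavy atoms (6 carbon, 1 oxygen; one six-membered aromatic ring of carbon only), on a saturated chain carbon bound to two saturated chain carbons and a saturated ring carbon.

For the measured compounds named here, no measured step bears directly on this exchange. Going by the values given here, the only step available, from compound 1 to compound 2, shows that swapping one aromatic group for another at a nearby position stayed within the scatter, so a modest step in this assay is expected here, with no direction favoured. For compound 3 the expected step is a 1.2-fold higher number from compound 2 to compound 3 (0.06 log units; within the scatter), and the estimated value is 60 nM, with a range from 20 nM to 200 nM.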

Compound 3, half-maximal inhibitory concentration: 30 nM
The estimate for compound 3 lay 2.0-fold (0.30 log units) above the measured number; the measured number falls inside the stated range.
By their numbers in this assay, from the lowest: compounds 3, 2 and 1 (each within the scatter of the next, the first and the last beyond it).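

In this assay, exchanging phenoxy for a group of 11 heavy atoms gives a 1.7-fold lower number from compound 2 to compound 3 (0.24 log units; within the scatter), so this saturated chain carbon accepted a group with 4 more heavy atoms without a change beyond the scatter. Compound 2 and compound 1 had shown only an aromatic exchange on a saturated ring carbon; this step is the first to show an exchange at the chain carbon itself, and the entering group brings nitrogen and sulfur, 3 hydrogen-bond acceptors in place of 1, and a double bond outside the aromatic ring. No measurement here bears on why the number stayed within the scatter.

The whole group changes in this single step, so the share of its sulfur, its nitrogen and its oxygens in the result cannot be separated. As far as these compounds go, how an amine or a cyclohexyl group would fare on the same saturated chain carbon also remains open.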